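Notes on a TRPM8 agonist series: the amide nitrogen substituent

A few compounds are considered here, and "the series" means these few. Any claim that something is new, unique, unknown or untested is made for them only; others in the source may bear on it.

Measured in an assay on HEK293 cells for agonist activity at transient receptor potential cation channel subfamily M member 8 (Homo sapiens), read by fluorescence and calcium flux, with a stated time of 15 min; a higher number here means that more compound is needed for the effect, a lower number that less compound is needed:
compound 1 `C=CCN(Cc1cccs1)C(=O)COc1ccc(C)cc1` gives 20 nM
compound 2 `CCN(Cc1ccsc1)C(=O)COc1ccc(C)cc1` gives 88 nM
compound 3 `CCN(Cc1cccs1)C(=O)COc1ccccc1` gives 1400 nM

Compound 1 stands at the lowest number of the three in this assay. The nearest of the others is compound 2, whose number is higher by a gap beyond the usual scatter; the furthest is compound 3, whose number is higher by a gap far beyond it. None of the three pairs differs in one place only, so no single step can be read from them.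

Compound 4 `Cc1ccc(OCC(=O)N(Cc2cccs2)c2nccn2C)cc1` is the next compound to be measured in this assay. Against compound 1 it differs in one place: 1-methyl-1H-imidazol-2-yl in place of allyl on an amide-type nitrogen. Going by the values given here, no measured pair shows this change, and nothing in the three measured compounds bears on an aromatic ring entering at this position. The step from compound 1 is therefore expected to be larger than the scatter, toward a higher number, as a 7.5-fold higher number from compound 1 to compound 4 (0.88 log units; beyond the scatter). For compound 4 the expected value in this assay is 150 nM, within 25 nM to 1000 nM.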

Compound 4, half-maximal effective concentration: 1790 nM
Compound 4: middle estimate off by 12-fold (1.08 log units), on the low side; the measured number lies above the stated range.
By their numbers in this assay, from the lowest: compound 1; then compound 2; then compounds 3 and 4 (each within the scatter of the next).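

In this assay, going by these compounds alone, 1-methyl-1H-imidazol-2-yl in place of allyl on the amide-type nitrogen gives a 90-fold higher number from compound 1 to compound 4 (1.95 log units; beyond the scatter), the first single-place reading at this position, and it shows that the position does not tolerate every replacement of allyl. The change brings in one five-membered aromatic ring with 2 hetero atoms and 2 hydrogen-bond acceptors, where allyl has no ring and 0 hydrogen-bond acceptors, and this one step cannot separate those features. No measurement at hand accounts for the size of the step.

Open, going by these compounds, is whether a phenyl ring or a propyl chain on this nitrogen would stay close to compound 1 or move toward compound 4. Also open, on these data alone, is how much allyl itself contributes, since the two ethyl compounds differ from compound 1 in more than one place.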